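The source may hold more compounds than are shown below. What is called first, only, known or untested is meant among the compounds shown, and "the series" means these compounds.

This study concerns an ADME assay on L02 cells (Homo sapiens) for antiproliferative activity, read by MTT assay, with a stated time of 48 h; a lower number here means a stronger inhibitor, a higher number a weaker inhibitor. Compound 1, with the structure `CC(=O)Nc1ccc(-n2nncc2CN2C(=O)C3(C(C#N)=C(N)Oc4c3c3nc5ccccc5nc3c3ccccc43)c3ccccc32)cc1`, has a result recorded only as a limit of this assay, > 50000 nM. Compound 2, with the structure `CCc1cccc(C)c1-n1nncc1CN1C(=O)C2(C(C#N)=C(N)Oc3c(N)cc4nc5ccccc5nc4c32)c2ccccc21`, likewise sits at a limit in this assay, > 50000 nM. Compound 2 therefore stands at the limit of > 50000 nM in this assay, at which 2 of the 2 values shown sit, the same position as compound 1, so no number separates the two. Compound 3, with the structure `N#CC1=C(N)Oc2c(N)cc3nc4ccccc4nc3c2C12C(=O)N(Cc1cnnn1-c1c(Cl)cc(Cl)cc1Cl)c1ccccc12`, has not yet been tested in this assay. Compound 3 differs from compound 2 in one place: 2,4,6-trichlorophenyl in place of 2-ethyl-6-methylphenyl on an aromatic nitrogen. Among the measured compounds shown here, no step between two measured compounds is recorded here, so nothing shows how such an exchange moves the read-out. The expected step is a number no higher from compound 2 to compound 3 (the limit leaves the size open), none beyond the usual scatter. Compound 3 is therefore expected to give about 50000 nM in this assay. For compound 3 the estimate spans from 20000 nM to 120000 nM, and a limit rather than a number is the more likely outcome.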

Compound 3, half-maximal inhibitory concentration: > 50000 nM
Compound 3: no number, only a limit; the forecaster's own chance of this, stated with the estimate: 75%; the middle value sits exactly at the limit.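

Compound 2 and compound 3 are each recorded only as a limit, not a number, so no step can be read between them in this assay. Whether 2,4,6-trichlorophenyl in place of 2-ethyl-6-methylphenyl changes the read-out at all stays open, and the compounds shown offer no contrast: the limit of > 50000 nM in this assay, at which 3 of the 3 values shown sit.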